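Swapping the Terminal Aryl Ring on a Shared Core

The source may hold more compounds than are shown below. What is called first, only, known or untested is meant among the compounds shown, and "the series" means these compounds.

Compound 3 `Cc1ccc(F)cc1-c1cccc(COc2ccc([C@H](CC(=O)O)c3nccn3C)cc2)c1` gives 36 nM in an assay on CHO cells for agonist activity at Free fatty acid receptor 1 (Homo sapiens), read by luminescence, with a stated time of 20 s, in the presence of a further agent that is not named here (a lower number here means that less compound is needed, a higher number that more compound is needed for the effect), the lowest of the three numbers, though all three lie within the usual scatter of one another: compound 1 `Cc1ccccc1-c1cccc(COc2ccc([C@H](CC(=O)O)c3nccn3C)cc2)c1` gives 43 nM and compound 2 `Cn1ccnc1[C@@H](CC(=O)O)c1ccc(OCc2cccc(-c3ccc(Cl)cc3Cl)c2)cc1` gives 69 nM. Compound 4 `COc1ccc(-c2cccc(COc3ccc([C@H](CC(=O)O)c4nccn4C)cc3)c2)cc1` has not yet been measured; it carries 4-methoxyphenyl in place of 5-fluoro-2-methylphenyl on an aromatic carbon. The earlier exchanges of this same terminal ring bear on it: the step of a 1.6-fold higher number from compound 1 to compound 2 (0.21 log units; within the scatter) and the step of a 1.9-fold lower number from compound 2 to compound 3 (0.28 log units; within the scatter) both stayed within the scatter, as did the smaller change a 1.2-fold lower number from compound 1 to compound 3 (0.08 log units; within the scatter). A further exchange at this position is therefore expected to give no step beyond the scatter, a 1.4-fold higher number from compound 3 to compound 4 (0.14 log units; within the scatter). Compound 4 is estimated at 50 nM, with a range from 20 nM to 130 nM.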

Compound 4, half-maximal effective concentration: 440 nM
The estimate for compound 4 lay 8.8-fold (0.94 log units) below the measured number, outside the stated range (above it).
By their numbers in this assay, from the lowest: compounds 3, 1 and 2 (each within the scatter of the next); then compound 4.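

In this assay the 4-methoxyphenyl ring gives a 12-fold higher number from compound 3 to compound 4 (1.09 log units; beyond the scatter) and a 10-fold higher number from compound 1 to compound 4 (1.01 log units; beyond the scatter) along with a 6.4-fold higher number from compound 2 to compound 4 (0.80 log units; beyond the scatter) so this position is less tolerant than the earlier exchanges, all within the scatter, had suggested. Not every terminal aryl ring is interchangeable here, even though this one enters in place of 5-fluoro-2-methylphenyl on the same aromatic carbon. No measurement at hand accounts for the rise.

The compounds shown leave open which feature of the new ring matters. A 4-methylphenyl or 4-hydroxyphenyl ring could show whether the methoxy group itself carries the change.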